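The source may report more compounds than this note shows. Statements on the series, on what has been measured and on what is new or still open speak of the compounds shown alone.

Values in a functional assay on HepG2 cells (Homo sapiens) for inhibition, read by sulforhodamine B assay, with a stated time of 24 h; a higher number here means a weaker inhibitor, a lower number a stronger inhibitor:

Compound 1 `Nc1ncnc2c1c(-c1ccccc1)cn2-c1ccc(S(=O)(=O)Nc2nccs2)cc1`: 4240 nM
Compound 2 `Nc1ncnc2c1c(-c1ccccc1)cn2-c1ccc(S(=O)(=O)Nc2ccccn2)cc1`: 4090 nM
Compound 3 `Nc1nc(=S)[nH]c2c1c(-c1ccccc1)cn2-c1ccc(S(=O)(=O)Nc2nccs2)cc1`: 4120 nM

From compound 1 to compound 2 the change is pyridin-2-yl in place of 1,3-thiazol-2-yl on a sulfonamide nitrogen. It gives a 1.0-fold lower number from compound 1 to compound 2 (0.02 log units; within the scatter), so the two numbers are indistinguishable here. Compound 3 carries a different core from compound 1; the difference between the two cores is not broken down here, and their values lie within the scatter of each other.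

Compound 4 `Nc1nc(=S)[nH]c2c1c(-c1ccccc1)cn2-c1ccc(S(=O)(=O)Nc2ccccn2)cc1` is compound 3 with pyridin-2-yl in place of 1,3-thiazol-2-yl on a sulfonamide nitrogen. The place of the change reads the same in both pairs, so this is the same change. Because the step of a 1.0-fold lower number from compound 1 to compound 2 (0.02 log units; within the scatter) lay within the scatter, a step of the same size, a 1.0-fold lower number from compound 3 to compound 4 (0.00 log units; within the scatter), is expected for this assay. Compound 4 is therefore estimated at 4100 nM, with the likely range 2000 nM to 8500 nM.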

Compound 4, half-maximal inhibitory concentration: 4100 nM
Beside the measured number, compound 4's estimate shows no gap at the digits printed, within the range that was stated.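

In this assay, pyridin-2-yl in place of 1,3-thiazol-2-yl on a sulfonamide nitrogen gives a 1.0-fold lower number from compound 3 to compound 4 (0.00 log units; within the scatter). Set beside the earlier pair, the two steps show no difference between the two cores: the same change on two cores in this assay, a 1.0-fold lower number (0.02 log units; within the scatter) from compound 1 to compound 2 and a 1.0-fold lower number (0.00 log units; within the scatter) from compound 3 to compound 4, 1.0-fold (0.01 log units) apart, within the scatter of two such steps. Among the compounds shown here, since neither step lies beyond the scatter, this shows only that the change has no detectable effect on either core, not that a real effect of a change at this place would carry from one core to the other, and it says nothing of any third core.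

Still open, as far as these compounds go, is how a sulfonamide nitrogen carrying an acetyl group or a simple methyl group would read in this assay, on either core.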